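The source may report more compounds than this note shows. Statements on the series, on what has been measured and on what is new or still open speak of the compounds shown alone.

The study compares cytotoxicity in a functional assay on KB cells (Homo sapiens) for cytotoxicity (a higher number here means that more compound is needed for the effect, a lower number that less compound is needed), across a small set of compounds sharing one core. Compound 1 `Cc1ccc2oc(-c3ccccc3)c(O)c(=O)c2c1` gives 2 ug/mL in this assay. Compound 2 `COc1ccc(-c2cc(=O)c3c(OC)c(OC)c(OC)c(OC)c3o2)c(OC)c1` gives 15 ug/mL, and compound 3 `C=CCOc1ccc(-c2cc(=O)c3c(OC)c(OC)c(OC)c(OC)c3o2)cc1` gives 26 ug/mL. Of these three numbers, compound 3 holds the highest, so more of it is needed for the effect than of either other measured compound. Its nearest neighbour is compound 2, whose number lies within the usual scatter of that of compound 3, so no order between the two can be drawn. Compound 1 stands furthest away, with a number well beyond the scatter below that of compound 3.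

Compound 4 `COc1c(OC)c(OC)c2c(=O)cc(-c3ccc(OC(C)=O)cc3)oc2c1OC` has not yet been measured in this assay. It differs from compound 3 in one place: acetyl in place of allyl on an oxygen on an aromatic ring. Within the data shown here, no pair of measured compounds differs by this change, so there is no measured step to lean on. The group that leaves and the group that enters match in their count of heavy atoms and neither carries a ring, while the entering group brings one hydrogen-bond acceptor. On this basis the step of a 1.2-fold lower number from compound 3 to compound 4 (0.07 log units; within the scatter) is expected to be none beyond the scatter. Compound 4 is therefore estimated at 22 ug/mL in this assay. For compound 4 the expected range runs from 8 ug/mL to 60 ug/mL.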

Compound 4, concentration for half-maximal effect: 3 ug/mL
Compound 4: the middle estimate sits 7.3-fold (0.87 log units) above what was measured; measured number below the stated range.
By their numbers in this assay, from the lowest: compounds 1 and 4 (each within the scatter of the next); then compounds 2 and 3 (each within the scatter of the next).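

In this assay, among these compounds, the replacement of allyl by acetyl on an oxygen on an aromatic ring gives an 8.7-fold lower number from compound 3 to compound 4 (0.94 log units; beyond the scatter) and so provides the first measured step in this set, as no two earlier compounds differed in only one place. It shows that the number responds to what is attached at this oxygen, even though the leaving and entering groups match in their count of heavy atoms and neither carries a ring. No measurement available here explains the size of this step.

A single step cannot show whether this result is particular to acetyl or would also appear with other groups on the same oxygen, such as a longer acyl chain, a carbamate or a free hydroxyl. Going by these compounds, it also remains open whether allyloxy to acetoxy would produce a similar step at another oxygen on the shared core or on a compound with a different substitution pattern.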